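The source may hold more compounds than are shown below. What is called first, only, known or untested is meant among the compounds shown, and "the series" means these compounds.

Measured compounds:
- compound 1 `C(=C/c1cccs1)\c1cc(-c2cccs2)cc(-c2cccs2)n1`: 118000 nM
- compound 2 `c1coc(-c2cc(-c3cccs3)nc(-c3cccs3)c2)c1`: 118000 nM

In a functional assay on SK-OV-3 cells (Female gonad, Homo sapiens) for antiproliferative activity (on this read-out higher numbers stand for an effect only at larger amounts of compound and lower numbers for an effect already at smaller amounts), compound 1 gives 118000 nM. In this assay compound 2 gives 118000 nM, and on these two numbers compound 2 stands level with compound 1; the difference, if any, is within the scatter of repeated measurements, so no order between the two can be read. Compound 3 `c1csc(-c2cc(-c3cccs3)nc(-c3cccs3)c2)c1` has not been measured. It differs from compound 2 in one place: thiophen-2-yl in place of furan-2-yl on an aromatic carbon. The change exchanges one five-membered aromatic ring bearing a single hetero atom for another of the same size and count, on the same aromatic carbon of the shared core. Within the data shown here, no measured pair shows the size of such a step here. Compound 3 is therefore expected to stay close to compound 2, with a step of no change at the digits printed from compound 2 to compound 3 (within the scatter) that does not go beyond the scatter. The estimate for compound 3 is 118000 nM, within a range from 50000 nM to 280000 nM.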

Compound 3, half-maximal effective concentration: 118000 nM
Compound 3: the middle estimate sits on the measured number at the digits printed; the measured number falls inside the stated range.
By their numbers in this assay, from the lowest: compounds 1, 2 and 3 (each within the scatter of the next).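

In this assay the exchange of furan-2-yl for thiophen-2-yl on the aromatic carbon opposite the ring nitrogen gives no change at the digits printed from compound 2 to compound 3 (within the scatter) and thus no difference can be read between these two five-membered rings at this position. Thiophen-2-yl in place of 2-(thiophen-2-yl)ethenyl gives no change at the digits printed from compound 1 to compound 3 (within the scatter) and so the ethenyl link, too, makes no readable difference here. Nothing available explains why these exchanges leave the read-out where it is.

As far as these compounds go, whether this position would respond to a different kind of group, such as an amine, a carboxylic acid or a longer alkyl chain, remains open. The compounds shown also leave open what the two thiophen-2-yl groups meta to this carbon contribute.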